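The compounds below may be only part of what the source reports. "The series", "measured", "known", "first", "only" and "open" are said of these compounds alone.

Compound 2 `CC/N=C(/N)Nc1nc(-c2ccc(OC)cc2)c(-c2ccc(OC)cc2)s1` is known in a functional assay with Oryctolagus cuniculus as the target (a lower number here means a stronger inhibitor, a higher number a weaker inhibitor), only as a limit, > 100 nM, and not as a number. Compound 1 `CNC(=N)Nc1nc(-c2ccc(OC)cc2)c(-c2ccc(OC)cc2)s1` gives 62 nM in this assay, and compound 3 `COc1ccc(-c2nc(CNC(C)=O)sc2-c2ccc(OC)cc2)cc1` gives 15 nM. Compound 4 `COc1ccc(-c2nc(CNC(=O)c3cccnc3)sc2-c2ccc(OC)cc2)cc1` has not yet been measured in this assay. The change from compound 2 to compound 4 is a group of 10 heavy atoms (7 carbon, 2 nitrogen, 1 oxygen; one six-membered aromatic ring with 1 hetero atom) in place of a group of 6 heavy atoms (3 carbon, 3 nitrogen; no ring), on an aromatic carbon. Among the compounds with values here, two measured steps bear on it: the step to compound 3, which is an at least 6.6-fold lower number from compound 2 to compound 3 (0.82 log units; beyond the scatter), and the related step of a 4.1-fold lower number from compound 1 to compound 3 (0.62 log units; beyond the scatter); both run toward a lower number when a group of 5 heavy atoms with 3 carbon, 1 nitrogen and 1 oxygen replaces the guanidine-like groups. Compound 4 carries the (((pyridin-3-yl)carbonyl)amino)methyl group at the same aromatic carbon, so a step of similar direction is expected. Compound 4 is therefore estimated at 22 nM, within 7 nM to 70 nM, a step of an at least 4.5-fold lower number from compound 2 to compound 4 (0.65 log units; beyond the scatter).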

Compound 4, half-maximal inhibitory concentration: 25 nM
Beside the measured number, compound 4's estimate is 1.1-fold (0.06 log units) below it, within the range that was stated.
By their numbers in this assay, from the lowest: compounds 3 and 4 (each within the scatter of the next); then compound 1. At a limit, above all of these: compound 2.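

In this assay, pyridin-3-yl in place of methyl on the carbonyl carbon gives a 1.7-fold higher number from compound 3 to compound 4 (0.22 log units; within the scatter) and so leaves compound 3 and compound 4 indistinguishable, which shows that this position accepts the added ring without a change beyond the scatter. Compound 4 also keeps an advantage over the guanidine-like group, with a 2.5-fold lower number from compound 1 to compound 4 (0.39 log units; beyond the scatter) as the step, so the lower number at this position is not confined to compound 3. Compound 2 is known only as a limit, so the step of an at least 4.0-fold lower number from compound 2 to compound 4 (0.60 log units; beyond the scatter) gives only a minimum size: the limit of > 100 nM in this assay, at which 1 of the 4 values shown sits.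

Going by these compounds, whether a simple amine or a carboxylic acid on this aromatic carbon would keep such numbers remains open. So does the effect of a longer chain in place of the pyridin-3-yl on the carbonyl carbon.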